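Working notes: from compound 3 to compound 4

This account rests on a few compounds, and the source may have more. Where it says the series, first, only, none or still open, it means among the compounds named here.

Measured in a physicochemical assay for lipophilicity; on this read-out lower numbers stand for lower lipophilicity and higher numbers for higher lipophilicity:
- compound 1 `Cn1nccc1-c1cc(C(F)(F)F)ccc1[C@H]1CCOc2cc(S(=O)(=O)Nc3nccs3)ccc21` gives 2.2
- compound 2 `O=S(=O)(Nc1nccs1)c1ccc2c(c1)OCC[C@@H]2c1ccc(C(F)(F)F)cc1-c1ccc(F)cn1` gives 3.5
- compound 3 `O=S(=O)(Nc1nccs1)c1ccc2c(c1)OCC[C@@H]2c1ccc(C(F)(F)F)cc1-c1nccs1` gives 3.3

Compound 3 is second highest of the three numbers, though the nearest gap is a number 0.20 log units lower from compound 2 to compound 3 (within the scatter). The furthest gap is a number 1.10 log units higher from compound 1 to compound 3 (beyond the scatter).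

Compound 4 `O=C1COCCN1c1cc(C(F)(F)F)ccc1[C@H]1CCOc2cc(S(=O)(=O)Nc3nccs3)ccc21` carries 3-oxomorpholin-4-yl in place of 1,3-thiazol-2-yl on an aromatic carbon. Among the measured compounds shown here, no measured compound carries the entering group. Exchanges on this carbon have given a number 1.30 log units higher from compound 1 to compound 2 (beyond the scatter) and a number 1.10 log units higher from compound 1 to compound 3 (beyond the scatter), so changes here can be large. The non-aromatic entering ring is expected to fall nearer compound 1, at 2.2, than compound 3. The expected change is a number 1.30 log units lower from compound 3 to compound 4 (beyond the scatter). For compound 4 the estimate in this assay is 2, with an expected range from 1.5 to 2.6.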

Compound 4, distribution coefficient: 1.8
For compound 4 the middle estimate is 0.20 log units above the measured one; the measured number falls inside the stated range.
By their numbers in this assay, from the lowest: compound 4; then compound 1; then compounds 3 and 2 (each within the scatter of the next).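

In this assay this aromatic carbon also takes a non-aromatic ring, and the number then drops well below those with aromatic rings: a number 1.50 log units lower from compound 3 to compound 4 (beyond the scatter) and a number 1.70 log units lower from compound 2 to compound 4 (beyond the scatter). The entering 3-oxomorpholin-4-yl also separates from 1-methyl-1H-pyrazol-5-yl, with a number 0.40 log units lower from compound 1 to compound 4 (beyond the scatter), leaving compound 4 with the lowest number of the four. No evidence on the origin of these steps is at hand.

Going by these compounds, whether a ring without the carbonyl, such as morpholine, would give a similar number remains open. So does the effect of an open-chain amide or a carboxylic acid on this carbon.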